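Pyridinyl Exchange Repeated on a Second Core

This account rests on a few compounds, and the source may have more. Where it says the series, first, only, none or still open, it means among the compounds named here.

Compound 1, `Nc1ccccc1NC(=O)c1ccc(CSC(=S)N2CCN(Cc3ccncc3)CC2)cc1`: 72.9%
Compound 2, `Nc1ccccc1NC(=O)c1ccc(CSC(=S)N2CCN(Cc3cccnc3)CC2)cc1`: 78%
Compound 3, `CN(Cc1ccncc1)C(=S)SCc1ccc(C(=O)Nc2ccccc2N)cc1`: 72.7%

In a functional assay on HeLa cells (Homo sapiens) for antiproliferative activity, read by CCK-8 assay, with a stated time of 72 h, tested at 8 uM (on this read-out higher numbers stand for a stronger effect at the one concentration tested and lower numbers for a weaker effect), compound 1 gives 72.9% and compound 2 gives 78%. Compound 2 differs from compound 1 by pyridin-3-yl in place of pyridin-4-yl on a saturated chain carbon bound to an amine nitrogen in a ring, and the step is a number 5.1 percentage points higher from compound 1 to compound 2 (within the scatter). Compound 3 gives 72.7% in this assay, a value that lies within the usual scatter of both other compounds. How the core of compound 3 differs from the core of compound 1 is not broken down here.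

Compound 4, `CN(Cc1cccnc1)C(=S)SCc1ccc(C(=O)Nc2ccccc2N)cc1`, has not been measured. It differs from compound 3 by pyridin-3-yl in place of pyridin-4-yl on a saturated chain carbon bound to an amide-type nitrogen. Within the data shown here, this is the same kind of change as the one from compound 1 to compound 2, but the surroundings of the place differ: there the carbon is bound to an amine nitrogen in a ring, here to an amide-type nitrogen. Because the earlier step of a number 5.1 percentage points higher from compound 1 to compound 2 (within the scatter) stayed within the scatter, the step of a number 4.3 percentage points higher from compound 3 to compound 4 (within the scatter) is expected to be of similar, small size. Compound 4 is therefore estimated at 77% in this assay, with a range from 65% to 87%.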

Compound 4, a percentage reported as inhibition, at one concentration (the size of the read-out at that concentration, not a potency): 68.7%
The estimate for compound 4 lay 8.3 percentage points above the measured number; the range from low to high includes it.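

In this assay, putting pyridin-3-yl in place of pyridin-4-yl on a saturated chain carbon bound to an amide-type nitrogen gives a step of a number 4 percentage points lower from compound 3 to compound 4 (within the scatter). Set beside the same change on the other core, the two steps do not differ beyond what repeated measurements allow: the same change on two cores in this assay, a number 5.1 percentage points higher (within the scatter) from compound 1 to compound 2 and a number 4 percentage points lower (within the scatter) from compound 3 to compound 4, 9.1 percentage points apart, within the scatter of two such steps. On these two pairs the change stays within the scatter on both cores, which fits a change of small size carrying over from one core to the other, but the opposite directions of the two steps cannot be read as a real reversal, and two pairs at a single concentration show neither a difference in potency nor how the change would behave on any further core.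

The compounds shown leave open whether pyridin-2-yl or a plain phenyl ring in the same place would also stay within the scatter on these cores. They also leave open whether a longer chain leading to the pyridinyl ring would do so.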